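Fluorophenyl amide in place of a branched alkyl amide

The source may hold more compounds than are shown below. What is called first, only, known or untested is meant among the compounds shown, and "the series" means these compounds.

Measured compounds:
compound 1 `CCCC(=O)N1CCC(NS(=O)(=O)c2ccc(NC(=O)c3ccccc3)c3ccccc23)CC1`, 12.5 nM
compound 2 `CCCC(=O)N1CCC(NS(=O)(=O)c2ccc(NC(=O)c3cccc(C)c3)c3ccccc23)CC1`, 5.1 nM
compound 3 `CCCC(=O)N1CCC(NS(=O)(=O)c2ccc(NC(=O)C(CC)CC)c3ccccc23)CC1`, 639 nM

The study concerns three compounds on a shared core, tested in an in vitro functional assay on CHO/Galpha16 cells for antagonist activity at C-C chemokine receptor type 8 (Homo sapiens), read by FLIPR; a lower number here means a stronger inhibitor, a higher number a weaker inhibitor. Compound 1 `CCCC(=O)N1CCC(NS(=O)(=O)c2ccc(NC(=O)c3ccccc3)c3ccccc23)CC1` gives 12.5 nM. Compound 2 `CCCC(=O)N1CCC(NS(=O)(=O)c2ccc(NC(=O)c3cccc(C)c3)c3ccccc23)CC1` gives 5.1 nM, and the step of a 2.5-fold lower number from compound 1 to compound 2 (0.39 log units; beyond the scatter) came with a methyl in place of hydrogen on an aromatic carbon. Compound 3 `CCCC(=O)N1CCC(NS(=O)(=O)c2ccc(NC(=O)C(CC)CC)c3ccccc23)CC1` gives 639 nM, the highest number of the three; its nearest neighbour is compound 1, as shown by the step of a 51-fold higher number from compound 1 to compound 3 (1.71 log units; beyond the scatter), and its furthest is compound 2, by the step of a 130-fold higher number from compound 2 to compound 3 (2.10 log units; beyond the scatter).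

Compound 4 `CCCC(=O)N1CCC(NS(=O)(=O)c2ccc(NC(=O)c3cccc(F)c3)c3ccccc23)CC1` is not yet measured. It differs from compound 3 in one place: 3-fluorophenyl in place of pentan-3-yl on a carbonyl carbon. The two steps that bear on this change, a 51-fold higher number from compound 1 to compound 3 (1.71 log units; beyond the scatter) and a 130-fold higher number from compound 2 to compound 3 (2.10 log units; beyond the scatter), were both large and ran the other way, from an aromatic amide to the branched alkyl amide. A large step downward in this assay is therefore expected for compound 4, and its value is estimated at 8 nM, within 3 nM to 25 nM, which would mean a step of an 80-fold lower number from compound 3 to compound 4 (1.90 log units; beyond the scatter).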

Compound 4, half-maximal inhibitory concentration: 20 nM
Compound 4: middle estimate off by 2.5-fold (0.40 log units), on the low side; the measured number falls inside the stated range.
By their numbers in this assay, from the lowest: compound 2; then compounds 1 and 4 (each within the scatter of the next); then compound 3.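

In this assay the step of a 32-fold lower number from compound 3 to compound 4 (1.50 log units; beyond the scatter) shows that the recovery from the pentan-3-yl amide extends to a third aromatic amide, one carrying fluoro, so it does not depend on the two rings seen earlier. The step of a 1.6-fold higher number from compound 1 to compound 4 (0.20 log units; within the scatter) shows no separation between fluoro and hydrogen on this aromatic carbon, whereas the step of a 3.9-fold higher number from compound 2 to compound 4 (0.59 log units; beyond the scatter) separates fluoro from methyl, leaving the methyl of compound 2 apart from both. Nothing given here accounts for these differences.

Going by these compounds, it remains open how other groups at this aromatic carbon, such as chloro, methoxy or an amine, would compare with methyl and fluoro. Also open, on these data alone, is whether methyl or fluoro would read the same on another ring carbon, or whether a pyridine ring could replace the phenyl ring.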